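The compounds below may be only part of what the source reports. "The series", "measured", "known", "first", "only" and "open" are said of these compounds alone.

Measured compounds and their values:
compound 1, `Nc1nc(Cl)c2ncn(Cc3ccccc3CCl)c2n1`, 19500 nM
compound 2, `ClCc1cccc(Cn2cnc3nc(Cl)nc(Cl)c32)c1`, 21400 nM
compound 3, `ClCc1ccc(Cn2cnc3c(Cl)nc(Cl)nc32)cc1`, 38000 nM

All three were tested in a functional assay on OVCAR-8 cells (Homo sapiens) for cytotoxicity, read by sulforhodamine B assay, with a stated time of 48 h; a lower number here means a stronger inhibitor of growth, a higher number a weaker inhibitor of growth. Compound 1 stands among three numbers that do not separate from one another: its nearest neighbour is compound 2, and its furthest is compound 3, yet both gaps lie within the usual scatter of repeated measurements, so no order among them can be read from these data. Compounds 2 and 3 share no single-point change with compound 1, so only their values can be compared.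

The account now follows compound 1 to compound 4, `ClCc1ccccc1Cn1cnc2c(Cl)ncnc21`, which has not yet been measured. The difference between the two structures is hydrogen in place of amino on an aromatic carbon. Going by the values given here, no measured pair illustrates this change, so the size of the step is uncertain. Given that compound 1 gives 19500 nM while the amino-free compounds 2 and 3 sit within the scatter of it, the step of a 1.3-fold higher number from compound 1 to compound 4 (0.11 log units; within the scatter) is expected to be small, with no clear direction beyond the scatter. Compound 4 is therefore estimated at 25000 nM, with a range of 10000 nM to 65000 nM.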

Compound 4, concentration for total growth inhibition: 5240 nM
Compound 4: middle estimate off by 4.8-fold (0.68 log units), on the high side, outside the stated range (below it).
By their numbers in this assay, from the lowest: compound 4; then compounds 1, 2 and 3 (each within the scatter of the next).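

In this assay, hydrogen in place of amino on an aromatic carbon, between two ring nitrogen atoms, gives a 3.7-fold lower number from compound 1 to compound 4 (0.57 log units; beyond the scatter) and this modest step lies beyond the scatter. Going by these compounds alone, the earlier compounds could not be separated from one another and offered no step at this position, so this is the first sign that the group held here can shift the number, though it rests on this single pair. Nothing measured on these compounds accounts for the shift.

Going by these compounds, it remains open whether another group at this place, such as a methyl, a hydroxyl or a methylamino group, would stay close to compound 4 or to compound 1. On these data alone, it is also open whether the step would hold if a methoxy group replaced the chloro group on the same ring.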